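This account rests on a few compounds, and the source may have more. Where it says the series, first, only, none or still open, it means among the compounds named here.

Three compounds share one core and differ only in the group attached to an aromatic nitrogen. Compound 1 `CC(C)n1ncc2c(C(=O)NCc3cn(-c4ccc([N+](=O)[O-])cc4)nn3)cccc21` carries a 4-nitrophenyl there, and in a functional assay on MCF7 cells (Homo sapiens) for inhibition, read by MTT assay, with a stated time of 72 h (on this read-out higher numbers stand for weaker inhibition and lower numbers for stronger inhibition), compound 1 gives > 40000 nM, which is a limit of the assay. Compound 2 `COc1ccc(-n2cc(CNC(=O)c3cccc4c3cnn4C(C)C)nn2)cc1` carries a 4-methoxyphenyl, and in this assay compound 2 gives > 40000 nM, also a limit. Among the compounds with values here, compound 3 `CC(C)n1ncc2c(C(=O)NCc3cn(Cc4ccccc4)nn3)cccc21` carries a benzyl, and in this assay compound 3 gives 9170 nM, the only actual number among the three. The two remaining values sit at the limit of > 40000 nM in this assay, at which 2 of the 3 values shown sit. The step of an at least 4.3-fold lower number from compound 1 to compound 3 (0.63 log units; beyond the scatter) and the step of an at least 4.3-fold lower number from compound 2 to compound 3 (0.63 log units; beyond the scatter) show that the benzyl gave stronger inhibition than either aryl group. The step that the two limits leave unreadable from compound 1 to compound 2, a change on an aromatic carbon, cannot be read.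

Compound 4 `CC(C)n1ncc2c(C(=O)NCc3cn(Cc4ccc(C(C)(C)C)cc4)nn3)cccc21` differs from compound 3 by tert-butyl in place of hydrogen on an aromatic carbon. Within the data shown here, no measured step changes a substituent on the benzyl, so none bears directly on this change, and the only comparison of substituents on an aromatic carbon, between compound 1 and compound 2, shows nothing readable. For compound 4 a step of a 1.1-fold lower number from compound 3 to compound 4 (0.06 log units; within the scatter) is therefore expected, within the scatter. The estimate for compound 4 in this assay is 8000 nM, with a range from 2000 nM to 35000 nM.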

Compound 4, half-maximal inhibitory concentration: > 40000 nM
Compound 4 was reported as a limit (the forecaster's own chance of this, stated with the estimate: 20%); middle value at least 5.0-fold (0.69 log units) away from the limit.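

In this assay, putting tert-butyl in place of hydrogen on an aromatic carbon of the benzyl group weakens inhibition, with an at least 4.3-fold higher number from compound 3 to compound 4 (0.63 log units; beyond the scatter). Within the data shown here, the earlier compounds showed only that benzyl gave stronger inhibition than either aryl group on the aromatic nitrogen, and their one change on an aromatic carbon could not be read; this step shows that the outcome also depends on what the benzyl ring carries, so the benzyl alone does not secure the inhibition seen with compound 3. Compound 3 is now the only compound shown with an actual number, and the others, compound 4 among them, give no ranking among themselves: the limit of > 40000 nM in this assay, at which 3 of the 4 values shown sit.

The compounds shown do not tell whether a single fluorine or a methyl group on the same ring carbon would keep the inhibition of compound 3, or whether an amine or a carboxylic acid there would behave like tert-butyl. They also leave open how a longer chain in place of the benzyl, with no substituent on its ring, would read in this assay.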